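Piperidin-1-yl to Diisopropylamino on the Thiocarbonyl Carbon

A few compounds are considered here, and "the series" means these few. Any claim that something is new, unique, unknown or untested is made for them only; others in the source may bear on it.

Of the compounds shown here, two have been measured in a functional assay on HeLa cells (Homo sapiens) for antiproliferative activity, read by MTT assay, with a stated time of 72 h; on this read-out higher numbers stand for weaker inhibition and lower numbers for stronger inhibition. Compound 1 `O=c1c(CSC(=S)N2CCCCC2)coc2cc(Cl)ccc12` gives 440 nM, the lower of the two numbers. Compound 2 `O=c1c(SC(=S)N2CCCCC2)coc2ccc(Cl)cc12` gives 8300 nM, a gap from compound 1 that lies beyond the usual scatter. Compound 3 `CC(C)N(C(=S)SCc1coc2cc(Cl)ccc2c1=O)C(C)C` is not yet measured; it differs from compound 1 in one place, (diisopropylamino in place of piperidin-1-yl on a thiocarbonyl carbon), a diisopropylamino in place of piperidin-1-yl on a thiocarbonyl carbon. Going by the values given here, no step between measured compounds of this kind exists to guide the size. A small step, if any beyond the scatter, is expected: a 1.4-fold higher number from compound 1 to compound 3 (0.13 log units; within the scatter). Compound 3 is therefore estimated at 600 nM, from 200 nM to 2000 nM.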

Compound 3, half-maximal inhibitory concentration: > 25000 nM
Compound 3 ended at the assay's limit; the forecaster's own chance of this, stated with the estimate: 3%; middle value at least 41-fold (1.61 log units) away from the limit.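

In this assay, the group on the thiocarbonyl carbon turns out not to be interchangeable: diisopropylamino in place of piperidin-1-yl gives an at least 56-fold higher number from compound 1 to compound 3 (1.75 log units; beyond the scatter). Going by these compounds alone, compounds 1 and 2 both carry piperidin-1-yl, so only this step shows that activity depends on the group at this place. The step has only a lower bound, as the value for compound 3 is a limit: the limit of > 25000 nM in this assay, at which 1 of the 3 values shown sits.

From the compounds shown here alone, whether the loss comes from opening the ring or from the isopropyl branches remains open. So does how pyrrolidin-1-yl, morpholin-4-yl or diethylamino would fare here.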